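A few compounds are considered here, and "the series" means these few. Any claim that something is new, unique, unknown or untested is made for them only; others in the source may bear on it.

In a functional assay on HCT-116 cells (Homo sapiens) for antiproliferative activity, read by sulforhodamine B assay, with a stated time of 72 h (a higher number here means a weaker inhibitor, a lower number a stronger inhibitor), compound 1 `Cn1ncc(Cl)c1-c1cc(C(=O)N[C@@H]2CN[C@H](CC(O)CO)C[C@H]2c2ccc(F)c(F)c2)oc1Cl` gives 800 nM and compound 2 `Cn1ncc(Cl)c1-c1cc(C(=O)N[C@@H]2CN[C@H](CCN3CCCCC3)C[C@H]2c2ccc(Cl)c(Cl)c2)oc1Cl` gives 1020 nM within the scatter of compound 1, although the two differ in more than one place. From compound 2 to compound 3 `Cn1ncc(Cl)c1-c1cc(C(=O)N[C@@H]2CN[C@H](CC(=O)NC3CC3)C[C@H]2c2ccc(Cl)c(Cl)c2)oc1Cl` the change is cyclopropylcarbamoyl in place of (piperidin-1-yl)methyl on a saturated chain carbon bound to a saturated ring carbon in full, that is, cyclopropylcarbamoyl in place of (piperidin-1-yl)methyl on a saturated chain carbon bound to a saturated ring carbon. Among the compounds with values here, no measured single-place step guides this change, and no shift beyond the scatter is expected in this assay for it. The expected change is a 1.1-fold lower number from compound 2 to compound 3 (0.05 log units; within the scatter) as estimated here. For compound 3 the estimate is 900 nM with an expected range of 350 nM to 2500 nM in this assay.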

Compound 3, half-maximal inhibitory concentration: 740 nM
Compound 3: middle estimate off by 1.2-fold (0.09 log units), on the high side, within the range that was stated.
By their numbers in this assay, from the lowest: compounds 3, 1 and 2 (each within the scatter of the next).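

In this assay cyclopropylcarbamoyl in place of (piperidin-1-yl)methyl on a saturated chain carbon bound to a saturated ring carbon gives a 1.4-fold lower number from compound 2 to compound 3 (0.14 log units; within the scatter). This single-place step is the only one in the series shown, and at this position it does not tell the two groups apart. No measured evidence accounts for this result. Open, from the compounds shown here alone, is whether a carboxylic acid, a primary amine or a longer chain at this place would give a step beyond the scatter.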